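The source may report more compounds than this note shows. Statements on the series, on what has been measured and on what is new or still open speak of the compounds shown alone.

Among the compounds with values here, in a functional assay (aorta) with Rattus norvegicus as the target (a higher number here means that more compound is needed for the effect, a lower number that less compound is needed), compound 1 `COc1ccc(-c2nc(/N=C(\N)N(C)C)sc2-c2ccc(OC)cc2)cc1` gives 4.8 uM and compound 2 `C/N=C(/NC)Nc1nc(-c2ccc(OC)cc2)c(-c2ccc(OC)cc2)s1` gives 2.4 uM while compound 3 `COc1ccc(-c2nc(CN(C)C)sc2-c2ccc(OC)cc2)cc1` gives 8.4 uM in the series so far. Compound 2 stands apart from only one of the others: a 2.0-fold lower number from compound 1 to compound 2 (0.30 log units; within the scatter) stays within the scatter while a 3.5-fold higher number from compound 2 to compound 3 (0.54 log units; beyond the scatter) goes beyond it. Going to compound 4 `COc1ccc(-c2nc(CNC(C)=O)sc2-c2ccc(OC)cc2)cc1` means a group of 5 heavy atoms (3 carbon, 1 nitrogen, 1 oxygen; no ring) in place of a group of 6 heavy atoms (3 carbon, 3 nitrogen; no ring), on an aromatic carbon and the entering group is acetamidomethyl. Within the data shown here, no measured compound carries that group. The closest guide is compound 3 at the same place, where a 3.5-fold higher number from compound 2 to compound 3 (0.54 log units; beyond the scatter) was modest and a 1.8-fold higher number from compound 1 to compound 3 (0.24 log units; within the scatter) stayed within the scatter. A modest rise of similar size is therefore expected in this assay for this change. The estimated step is a 3.3-fold higher number from compound 2 to compound 4 (0.52 log units; beyond the scatter) on present evidence. Compound 4 is expected at 8 uM with an estimated range of 3 uM to 25 uM until measured.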

Compound 4, concentration for half-maximal effect: 8.1 uM
Estimate against measurement, compound 4: 1.0-fold (0.01 log units) below; the range from low to high includes it.
By their numbers in this assay, from the lowest: compounds 2, 1, 4 and 3 (each within the scatter of the next, the first and the last beyond it).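

In this assay, acetamido in place of dimethylamino on the saturated chain carbon leaves the number unchanged within the scatter: a 1.0-fold lower number from compound 3 to compound 4 (0.02 log units; within the scatter). The step of a 1.7-fold higher number from compound 1 to compound 4 (0.23 log units; within the scatter) also stays within the scatter, whereas a 3.4-fold higher number from compound 2 to compound 4 (0.53 log units; beyond the scatter) goes beyond it, the same split seen with compound 3. Nothing available explains this result. Going by these compounds, a primary amine, a carboxylic acid or a longer chain at this place remains open. On these data alone, it is also open whether any such group would give a number nearer that of compound 2 or those of compound 3 and compound 4.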